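The source may report more compounds than this note shows. Statements on the series, on what has been measured and on what is new or still open speak of the compounds shown alone.

Measured so far in a functional assay on HepG2 cells (Homo sapiens) for inhibition, read by MTT assay, with a stated time of 72 h; on this read-out lower numbers stand for stronger inhibition and higher numbers for weaker inhibition:
compound 1 `O=C(Nc1ccc(Oc2ccnc3[nH]ccc23)cc1)c1cn(-c2ccccc2)c2ccccc2c1=O`, 2250 nM;
compound 2 `O=C(Nc1ccc(Oc2ccnc3[nH]ccc23)cc1)c1cn(-c2ccc(F)cc2)c2ccccc2c1=O`, 450 nM.

Compound 2 gives the lower of the two numbers, and the only step shown, a 5.0-fold lower number from compound 1 to compound 2 (0.70 log units; beyond the scatter), separates it from compound 1. Compound 3 `O=C(Nc1ccc(Oc2ccnc3[nH]ccc23)cc1)c1cn(-c2ccc(Cl)cc2)c2ccccc2c1=O` carries a further change at the same place: chloro in place of fluoro on an aromatic carbon, para to a large group. Within the data shown here, no measured step exchanges one halogen for another, so the earlier step bears on this one only indirectly, showing that a halogen is tolerated here. Compound 3 is therefore expected to stay close to compound 2, with a 1.3-fold lower number from compound 2 to compound 3 (0.11 log units; within the scatter) as the estimated step. The estimate for compound 3 is 350 nM, within 120 nM to 1200 nM.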

Compound 3, half-maximal inhibitory concentration: 250 nM
The estimate for compound 3 lay 1.4-fold (0.15 log units) above the measured number; the measured number falls inside the stated range.
By their numbers in this assay, from the lowest: compounds 3 and 2 (each within the scatter of the next); then compound 1.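

Swapping one halogen for the other at this position does not clearly change the result in this assay (step: a 1.8-fold lower number from compound 2 to compound 3 (0.26 log units; within the scatter)), so compound 2 and compound 3 cannot be told apart. The improvement over the unsubstituted ring is therefore not unique to fluoro, since chloro in place of hydrogen also clears the scatter (step: a 9.0-fold lower number from compound 1 to compound 3 (0.95 log units; beyond the scatter)). No measurement shown here explains why a halogen helps. Going by these compounds, whether a methyl, a methoxy or a trifluoromethyl group at this place would do as well remains open.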